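The compounds below may be only part of what the source reports. "The series", "measured", "known", "first", "only" and "open" are said of these compounds alone.

Measured so far:
compound 1 `CCCC(C)n1c(CC)nc2c(-c3ccc(C(C)OC)cc3Cl)ccnc21`, 3.5 nM
compound 2 `CCCC(C)n1c(CC)nc2c(-c3cc(F)c(F)cc3Cl)ccnc21`, 2.4 nM

In an assay for binding affinity to Corticotropin releasing factor receptor (Rattus norvegicus) (a lower number here means a stronger inhibitor, a higher number a weaker inhibitor), compound 1 gives 3.5 nM and compound 2 gives 2.4 nM; the two numbers lie within the usual scatter of each other, so compound 1 stands level with compound 2 rather than apart from it. Compound 3 `CCCC(C)n1c(CC)nc2c(-c3ccc(Cl)cc3Cl)ccnc21` is not yet measured. It differs from compound 1 in one place: chloro in place of 1-methoxyethyl on an aromatic carbon. Among the measured compounds shown here, no measured pair covers this change, so the step is expected to stay within the scatter, in no fixed direction. For compound 3 the estimated value is 3 nM, with a range from 1 nM to 10 nM. The expected step is a 1.2-fold lower number from compound 1 to compound 3 (0.07 log units; within the scatter).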

Compound 3, inhibition constant: 0.5 nM
Beside the measured number, compound 3's estimate is 6.0-fold (0.78 log units) above it, outside the stated range (below it).
By their numbers in this assay, from the lowest: compound 3; then compounds 2 and 1 (each within the scatter of the next).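

In this assay, chloro in place of 1-methoxyethyl on the aromatic carbon meta to a chloro group gives a 7.0-fold lower number from compound 1 to compound 3 (0.85 log units; beyond the scatter). Among the compounds shown here, this is the first step that lies beyond the scatter, so the number at this position does respond to the group it carries. One pair cannot separate the loss of heavy atoms from the loss of the hydrogen-bond acceptor, and no measurement here accounts for the step. Still open, as far as these compounds go, is how methoxy, methyl or an amine would read at this position, and whether the step holds with other groups elsewhere on the shared core.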